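Propargyl ether in a brominated diaryl ether series

The compounds below may be only part of what the source reports. "The series", "measured", "known", "first", "only" and "open" are said of these compounds alone.

Compounds and values: compound 1 `BrCCCOc1c(Br)cc(Br)cc1Oc1ccc(Br)cc1Br`, 30.3 ug/mL; compound 2 `BrCCCCCOc1c(Br)cc(Br)cc1Oc1ccc(Br)cc1Br`, 29.5 ug/mL; compound 3 `Brc1ccc(Oc2cc(Br)cc(Br)c2OCc2ccccc2)c(Br)c1`, 29 ug/mL.

All three were tested in a functional assay on U-937 cells (Homo sapiens) for cytotoxicity, read by MTT assay, with a stated time of 24 h; on this read-out higher numbers stand for weaker inhibition and lower numbers for stronger inhibition. Compound 1 sits alongside the other two: a 1.0-fold lower number from compound 1 to compound 2 (0.01 log units; within the scatter) and a 1.0-fold lower number from compound 1 to compound 3 (0.02 log units; within the scatter), and between the other two a 1.0-fold lower number from compound 2 to compound 3 (0.01 log units; within the scatter). Compound 4 `C#CCOc1c(Br)cc(Br)cc1Oc1ccc(Br)cc1Br` is not yet measured; it differs from compound 1 by ethynyl in place of 2-bromoethyl on a saturated chain carbon bound to an oxygen on an aromatic ring. Every measured step also swaps the group on that same saturated chain carbon, and none of them moved the number beyond the scatter. The expected step is therefore a 1.0-fold lower number from compound 1 to compound 4 (0.00 log units; within the scatter), with no direction beyond the scatter. Compound 4 is estimated at 30 ug/mL, within 20 ug/mL to 45 ug/mL.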

Compound 4, half-maximal inhibitory concentration: 29.5 ug/mL
Compound 4: the middle estimate sits 1.0-fold (0.01 log units) above what was measured; measured number inside the range.
By their numbers in this assay, from the lowest: compounds 3, 2, 4 and 1 (each within the scatter of the next).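

With ethynyl on the saturated chain carbon bound to an oxygen on an aromatic ring, the number in this assay stays within the scatter of all three earlier compounds (a 1.0-fold lower number from compound 1 to compound 4 (0.01 log units; within the scatter)) (a 1.0-fold higher number from compound 3 to compound 4 (0.01 log units; within the scatter)) (no change at the digits printed from compound 2 to compound 4 (within the scatter)). This place therefore also accepts a group with a triple bond outside aromatic rings, alongside the bromoalkyl chains and the phenyl, with no step beyond the scatter in any of the four compounds. Nothing in the available data explains this flatness. From the compounds shown here alone, whether an amine or a carboxylic acid at this place would leave the number just as unmoved stays open.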